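The source may report more compounds than this note shows. Statements on the series, on what has been measured and on what is new or still open speak of the compounds shown alone.

In a functional assay on WiDr cells (Homo sapiens) for inhibition, read by sulforhodamine B assay, with a stated time of 48 h (on this read-out lower numbers stand for stronger inhibition of growth and higher numbers for weaker inhibition of growth), compound 1 `COC(=O)[C@@]1(C)CCC=C2[C@@H]1CC[C@@H](C)[C@]2(C)Cc1c[nH]c2ccc(C)cc12` gives 22000 nM. Compound 2 `COC(=O)[C@@]1(C)CCC=C2[C@@H]1CC[C@@H](C)[C@]2(C)Cc1c[nH]c2ccc(Br)cc12` differs from it by bromo in place of methyl on an aromatic carbon, and in this assay compound 2 gives 20000 nM, so the step of a 1.1-fold lower number from compound 1 to compound 2 (0.04 log units; within the scatter) is a small one. Compound 3 `COC(=O)[C@@]1(C)CCC=C2[C@@H]1CC[C@@H](C)[C@]2(C)Cc1c[nH]c2c(C)cccc12` is built from the same atoms as compound 1, joined differently; the difference between the two cores is not broken down here. In this assay compound 3 gives 26000 nM, and all three measured values sit close together.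

Compound 4 `COC(=O)[C@@]1(C)CCC=C2[C@@H]1CC[C@@H](C)[C@]2(C)Cc1c[nH]c2c(Br)cccc12` has not yet been measured. It differs from compound 3 by bromo in place of methyl on an aromatic carbon. Going by the values given here, this is the same kind of change as the one between compound 1 and compound 2, though the place is not word for word the same: in compound 2 the bromo sits meta to a fused ring and para to a fused ring, while in compound 4 it sits ortho to a fused ring and meta to a fused ring. The earlier step, a 1.1-fold lower number from compound 1 to compound 2 (0.04 log units; within the scatter), stayed within the scatter. On that basis the expected step is a 1.1-fold lower number from compound 3 to compound 4 (0.03 log units; within the scatter). Compound 4 is thus estimated at 24000 nM in this assay, with a likely range from 12000 nM to 48000 nM.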

Compound 4, concentration for 50% growth inhibition: 32000 nM
Compound 4: middle estimate off by 1.3-fold (0.12 log units), on the low side; the measured number falls inside the stated range.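

In this assay, putting bromo in place of methyl on an aromatic carbon of the core of compound 3 gives a 1.2-fold higher number from compound 3 to compound 4 (0.09 log units; within the scatter). Set beside the same change on the core of compound 1, the two steps do not differ beyond what repeat measurements would produce: the same change on two cores in this assay, a 1.1-fold lower number (0.04 log units; within the scatter) from compound 1 to compound 2 and a 1.2-fold higher number (0.09 log units; within the scatter) from compound 3 to compound 4, 1.4-fold (0.13 log units) apart, within the scatter of two such steps. So in these two pairs the change leaves growth inhibition about where it was, which fits with carrying it from one core to the other, but steps this small cannot show whether the two cores truly respond alike, nor how the change would behave on any other core.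

The compounds shown leave open what other groups on the aromatic ring would do, such as an amine or a longer chain in place of the methyl or bromo. They also leave open whether a carboxylic acid in place of the ester on the shared core would move the numbers at all.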